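This account rests on a few compounds, and the source may have more. Where it says the series, first, only, none or still open, it means among the compounds named here.

Three compounds share one core and differ only in the group on the amide-type nitrogen. Compound 1 `Cn1cc(-c2cnc3c(-c4csc(C(=O)N[C@@H]5CCC[C@@H]5O)c4)cnn3c2)cn1` carries a 2-hydroxycyclopentyl group and in an assay for inhibition of MAP/microtubule affinity-regulating kinase 3 (Homo sapiens), read by HTRF, with a stated time of 2 h (on this read-out lower numbers stand for stronger inhibition and higher numbers for weaker inhibition), compound 1 gives 43 nM. Compound 2 `Cn1cc(-c2cnc3c(-c4csc(C(=O)N[C@@H]5CCC[C@H]5N)c4)cnn3c2)cn1` gives 3 nM, and compound 3 `Cn1cc(-c2cnc3c(-c4csc(C(=O)N[C@@H]5CCCC[C@H]5N)c4)cnn3c2)cn1` gives 1 nM. Compound 2 thus holds the second highest number of the three: its nearest neighbour is compound 3, with a 3.0-fold lower number from compound 2 to compound 3 (0.48 log units; beyond the scatter), and its furthest is compound 1, with a 14-fold lower number from compound 1 to compound 2 (1.16 log units; beyond the scatter) separating the two.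

Compound 4 `Cn1cc(-c2cnc3c(-c4csc(C(=O)N[C@@H]5CCCC[C@@H]5O)c4)cnn3c2)cn1` has not been measured. Its change from compound 2 is a group of 7 heavy atoms (6 carbon, 1 oxygen; one six-membered non-aromatic ring of carbon only) in place of a group of 6 heavy atoms (5 carbon, 1 nitrogen; one five-membered non-aromatic ring of carbon only), on an amide-type nitrogen. Within the data shown here, two measured steps bear on it. The exchange of the amino group for a hydroxyl runs opposite to the step of a 14-fold lower number from compound 1 to compound 2 (1.16 log units; beyond the scatter), so it should raise the number considerably. The growth from a five- to a six-membered ring echoes a 3.0-fold lower number from compound 2 to compound 3 (0.48 log units; beyond the scatter), which lowers it modestly. Together the larger rise is expected to dominate, and compound 4 is expected to show a 5.0-fold higher number from compound 2 to compound 4 (0.70 log units; beyond the scatter). Compound 4 is therefore estimated at 15 nM, within a range of 5 nM to 45 nM.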

Compound 4, half-maximal inhibitory concentration: 9 nM
Compound 4: middle estimate off by 1.7-fold (0.22 log units), on the high side; the measured number falls inside the stated range.
By their numbers in this assay, from the lowest: compound 3; then compound 2; then compound 4; then compound 1.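

With compound 4, both changes on the amide-type nitrogen can now be read in both settings. Growth from the five- to the six-membered ring also lowers the number when the ring carries a hydroxyl, a 4.8-fold lower number from compound 1 to compound 4 (0.68 log units; beyond the scatter), in the same direction as with the amino group, a 3.0-fold lower number from compound 2 to compound 3 (0.48 log units; beyond the scatter). Hydroxyl in place of amino raises the number on the six-membered ring, a 9.0-fold higher number from compound 3 to compound 4 (0.95 log units; beyond the scatter), as it does on the five-membered ring, and with both changes together the number still ends higher, a 3.0-fold higher number from compound 2 to compound 4 (0.48 log units; beyond the scatter), so the ring growth offsets only part of that rise.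

Nothing in the material shown gives a reason for these differences. The compounds shown leave open whether a seven-membered carbon ring or a methoxy group in place of the hydroxyl would follow the same pattern.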